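The source may report more compounds than this note shows. Statements on the series, on what has been measured and on what is new or still open speak of the compounds shown alone.

Measured compounds:
compound 1 `CC(C)(O)CNC(=O)c1nc(CC2CCCCC2)c(-c2cnc(S(=O)(=O)NC(C)(C)C)c3ccccc23)s1`: < 4000 nM in a physicochemical assay for solubility, read by HPLC, in phosphate buffer, measured as thermodynamic solubility, with a stated time of 5 days, at pH 2, tested at 10 mM; a higher number here means a more soluble compound, a lower number a less soluble compound
compound 2 `CC(C)(C)NS(=O)(=O)c1ccc(-c2sc(C(=O)N[C@H]3C[C@H](C(=O)O)C3)nc2CC2CCCCC2)c(C(F)(F)F)c1`: < 4000 nM in this assay

Where compound 2 stands: in this assay compound 2 returns only a limit, < 4000 nM, not a number. Compound 1 likewise sits at a limit, < 4000 nM, in this assay. For the measured compounds named here, both readings therefore rest on (the limit of < 4000 nM in this assay, at which 2 of the 2 values shown sit), and no step between two measured compounds is available to set the size or direction of any change within this pair.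

Compound 3 `CC(C)(C)NS(=O)(=O)c1ccc(-c2sc(C(=O)N[C@H]3C[C@H](C(=O)O)C3)nc2CC2CCCCC2)c(Cl)c1` is the unmeasured analogue of compound 2. The change is chloro in place of trifluoromethyl on an aromatic carbon, on an aromatic carbon of a six-membered aromatic ring of carbon only, ortho to a large group and meta to the (tert-butyl)sulfamoyl group. Going by the values given here, with both measured values sitting at the limit of < 4000 nM in this assay, at which 2 of the 2 values shown sit, there is no measured step to lean on for this change. The expected step, a step that the limit leaves unreadable from compound 2 to compound 3, is small and of no settled direction, within the usual scatter. Compound 3 is expected to remain near or at the limit in this assay. Estimated solubility for compound 3 in this assay: 2500 nM, within 600 nM to 8000 nM.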

Compound 3, solubility: < 1000 nM
Compound 3: no number, only a limit; the forecaster's own chance of this, stated with the estimate: 70%; at least 2.5-fold (0.39 log units) between middle value and limit.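

In this assay compound 3 gives < 1000 nM, a limit and not a number. For the compounds shown here, compound 2 also gives only a limit, < 4000 nM, so no step from compound 2 to compound 3 can be read. The compounds shown leave open whether chloro or trifluoromethyl on this aromatic carbon gives the higher solubility.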